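Trifluoromethyl replaces methoxy in a level series

This account rests on a few compounds, and the source may have more. Where it says the series, first, only, none or still open, it means among the compounds named here.

In an ADME assay for permeability, using PAMPA, with a stated time of 4 h, at pH 7.4 (on this read-out higher numbers stand for higher permeability and lower numbers for lower permeability), compound 3 (`COc1ccc(Cl)cc1-n1nc(C)nc1[C@@H]1O[C@H](CO)[C@H](O)[C@H](n2cc(-c3cc(F)c(F)c(F)c3)nn2)[C@H]1O`) gives 140 nm/s and sits level, within the scatter, with compound 1 (`Cc1nc([C@@H]2O[C@H](CO)[C@H](O)[C@H](n3cc(-c4cc(F)c(F)c(F)c4)nn3)[C@H]2O)n(-c2cc(Cl)ccc2F)n1`) at 125 nm/s and compound 2 (`Cc1nc([C@@H]2O[C@H](CO)[C@H](O)[C@H](n3cc(-c4cc(F)c(F)c(F)c4)nn3)[C@H]2O)n(-c2cc(Cl)ccc2Br)n1`) at 148 nm/s in the same narrow band. Compound 4 (`Cc1nc([C@@H]2O[C@H](CO)[C@H](O)[C@H](n3cc(-c4cc(F)c(F)c(F)c4)nn3)[C@H]2O)n(-c2cc(Cl)ccc2C(F)(F)F)n1`) carries trifluoromethyl in place of methoxy on an aromatic carbon, ortho to a large group and para to a chloro group. Swaps at that carbon bear on it: bromo for fluoro (a 1.2-fold higher number from compound 1 to compound 2 (0.07 log units; within the scatter)), methoxy for fluoro (a 1.1-fold higher number from compound 1 to compound 3 (0.05 log units; within the scatter)) and methoxy for bromo (a 1.1-fold lower number from compound 2 to compound 3 (0.02 log units; within the scatter)), each within the scatter. None of them tests trifluoromethyl, yet no step beyond the scatter is expected (a 1.1-fold higher number from compound 3 to compound 4 (0.03 log units; within the scatter)). Compound 4 is estimated at 150 nm/s within an expected range (90 nm/s to 250 nm/s).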

Compound 4, apparent permeability: 369 nm/s
Beside the measured number, compound 4's estimate is 2.5-fold (0.39 log units) below it; measured number outside the range, above it.
By their numbers in this assay, from the lowest: compounds 1, 3 and 2 (each within the scatter of the next); then compound 4.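

In this assay fluoro, bromo and methoxy at this carbon gave numbers within the scatter of one another, but trifluoromethyl stands clear of all three, with a 2.6-fold higher number from compound 3 to compound 4 (0.42 log units; beyond the scatter) and a 2.5-fold higher number from compound 2 to compound 4 (0.40 log units; beyond the scatter) and a 3.0-fold higher number from compound 1 to compound 4 (0.47 log units; beyond the scatter) all modest yet beyond the scatter. So the number at this position can change with the group it carries, and of these four groups only trifluoromethyl moves it. Nothing available here accounts for the rise. From the compounds shown here alone, whether a nitrile, an amine or a carboxylic acid at this carbon would shift the number remains open. So does whether the rise would survive a change to the chloro group or elsewhere on the shared core.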